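A nitro compound redrawn without its double-bond configuration

The source may hold more compounds than are shown below. What is called first, only, known or untested is meant among the compounds shown, and "the series" means these compounds.

Values in a functional assay on T98G cells (Homo sapiens) for cytotoxicity, read by MTT assay, with a stated time of 48 h; on this read-out lower numbers stand for stronger inhibition and higher numbers for weaker inhibition:
compound 1 `C/C(=N/NC(=S)Nc1ccccc1)c1ccccn1` gives 6.81 nM
compound 2 `C/C(=N/NC(=S)Nc1ccc(Cl)cc1)c1ccccn1` gives 5.9 nM
compound 3 `C/C(=N/NC(=S)Nc1ccc([N+](=O)[O-])cc1)c1ccccn1` gives 140 nM

Compound 3 has the highest number of the three, which on this read-out means the weakest inhibition. Its place is set by two large steps, a 21-fold higher number from compound 1 to compound 3 (1.31 log units; beyond the scatter) and a 24-fold higher number from compound 2 to compound 3 (1.38 log units; beyond the scatter), each of which brings in the nitro group. Chloro in place of hydrogen, by contrast, gave a 1.2-fold lower number from compound 1 to compound 2 (0.06 log units; within the scatter) and stays within the scatter.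

Compound 4 `CC(=NNC(=S)Nc1ccc([N+](=O)[O-])cc1)c1ccccn1` has the same atoms and bonds as compound 3, and the only difference lies in the drawing: the two compounds have the same atoms and bonds; at least one stereo element is drawn with a configuration in one of them and without one in the other: 1 of 1 stereo elements differ; a double bond is drawn Z in compound 3 and without a configuration in compound 4. Among the measured compounds shown here, none of the measured steps tests a change of this kind, since all three swap a group on an aromatic carbon, while compound 4 keeps the nitro group. The nitro steps therefore fix the level to start from and do not predict a further shift. The data do not show which double-bond form, or mixture of forms, compound 4 represents, so the range is kept fairly wide. An expected no change at the digits printed from compound 3 to compound 4 (within the scatter) would stay within the scatter, with no change in either direction anticipated in this assay. Compound 4 is estimated at 140 nM with an expected range of 60 nM to 320 nM once it is measured.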

Compound 4, half-maximal inhibitory concentration: 140 nM
Beside the measured number, compound 4's estimate shows no gap at the digits printed; the range from low to high includes it.
By their numbers in this assay, from the lowest: compounds 2 and 1 (each within the scatter of the next); then compounds 3 and 4 (each within the scatter of the next).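

In this assay, among the compounds shown here, there is no change at the digits printed from compound 3 to compound 4 (within the scatter), and this is the first step that leaves every atom and bond in place and alters only how the structure is drawn. The earlier steps shown here all swapped a group on an aromatic carbon, so they could not show whether the high number seen with the nitro group would hold up when the same connectivity appeared as a second entry; here it does, and that number now rests on two entries instead of one. What separates those two entries is a matter of drawing alone: the fact that one of compounds 3 and 4 is drawn with a defined configuration and the other without, at the place where they differ

The drawing of compound 4 does not tell which double-bond form, or mixture of forms, lies behind its number, so the effect of the double-bond geometry itself remains an open question, and this step cannot be read as showing that geometry has no effect. Also open, on these data alone, is how the number would respond to other groups in the place held by the nitro group, such as a methoxy group or an amine.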